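Removing one methyl from compound 1

The source may hold more compounds than are shown below. What is called first, only, known or untested is meant among the compounds shown, and "the series" means these compounds.

For the measured compounds named here, in a functional assay on cells (Cancer cell lines, Homo sapiens) for inhibition (a lower number here means a stronger inhibitor of growth, a higher number a weaker inhibitor of growth), compound 1 (`Cc1cc(-c2nc3sc(C)cn3c2/C=N/NC(=N)N)c(C)s1`) gives 4470 nM and holds the lower of the two numbers so far. In this assay compound 2 (`N=C(N)N/N=C/c1c(-c2cc(Cl)sc2Cl)nc2n1CCS2`) gives 12300 nM as the higher number, a gap beyond the scatter. Compound 3 (`Cc1cc(-c2nc3sccn3c2/C=N/NC(=N)N)c(C)s1`) has hydrogen in place of methyl on an aromatic carbon and is still unmeasured. Going by the values given here, no measured pair shows this kind of change. The estimate is therefore a 1.1-fold higher number from compound 1 to compound 3 (0.05 log units; within the scatter) in this assay and is expected to stay within the scatter. Compound 3 is expected at 5000 nM with an estimated range from 2000 nM to 12000 nM for its growth inhibition.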

Compound 3, concentration for 50% growth inhibition: 16200 nM
Compound 3: the middle estimate sits 3.2-fold (0.51 log units) below what was measured, outside the stated range (above it).
By their numbers in this assay, from the lowest: compound 1; then compounds 2 and 3 (each within the scatter of the next).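

In this assay, hydrogen in place of methyl on the aromatic carbon next to the ring sulfur gives a 3.6-fold higher number from compound 1 to compound 3 (0.56 log units; beyond the scatter), a modest step beyond the scatter. For the compounds shown here, this is the first pair that differs in one place, and it shows that growth inhibition in these compounds is sensitive to this single methyl. Nothing available explains the step.

The compounds shown leave open whether a larger group at this carbon, such as ethyl, or a different one, such as an amine, would match or exceed methyl.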